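Replacing a Long Chain with a Phenyl Ring

The source may report more compounds than this note shows. Statements on the series, on what has been measured and on what is new or still open speak of the compounds shown alone.

In a functional assay on brain (Rattus norvegicus, strain Wistar) for inhibition (a lower number here means a stronger inhibitor, a higher number a weaker inhibitor), compound 1 `CCCCCCCOc1ccc(-c2c(C)[nH]c(=O)n2C2CCCCC2)cc1` gives 11600 nM and compound 2 `CCCCCCCCOc1ccc(-c2c(C)[nH]c(=O)n2C2CCCCC2)cc1` gives 8500 nM. Among the measured compounds shown here, these two values lie within the scatter of each other, so compound 2 stands level with the only other measured compound.

Compound 3 `Cc1[nH]c(=O)n(C2CCCCC2)c1-c1ccc(-c2ccccc2)cc1` alters the group that carries this chain: phenyl in place of octyloxy on an aromatic carbon. Put simply, it has phenyl in place of octyloxy on an aromatic carbon, para to a large group.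

For the measured compounds named here, only one measured step bears on this change. Extending the chain by a methyl in place of hydrogen gives a 1.4-fold lower number from compound 1 to compound 2 (0.14 log units; within the scatter), so this small edit at the chain end does not shift the number beyond the scatter. Going by the values given here, that step is a weak guide, however, as no measured compound lacks the long chain and the new change is far larger.

With so little evidence, a modest move towards a higher number, meaning a weaker inhibitor, is expected: a 1.8-fold higher number from compound 2 to compound 3 (0.25 log units; within the scatter). Compound 3 is estimated at 15000 nM, with an expected range from 4000 nM to 60000 nM.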

Compound 3, half-maximal inhibitory concentration: 10900 nM
The estimate for compound 3 lay 1.4-fold (0.14 log units) above the measured number, within the range that was stated.
By their numbers in this assay, from the lowest: compounds 2, 3 and 1 (each within the scatter of the next).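

In this assay, the long chain turns out not to be needed to keep the number where it is: phenyl in place of octyloxy gives a 1.3-fold higher number from compound 2 to compound 3 (0.11 log units; within the scatter), and phenyl in place of heptyloxy gives a 1.1-fold lower number from compound 1 to compound 3 (0.03 log units; within the scatter). The group that enters has fewer heavy atoms, a ring instead of a chain and no hydrogen-bond acceptor, yet compound 3 stands level with both chain compounds, so among these three compounds neither the chain nor its oxygen is required for this level of inhibition. No accompanying measurement explains why such different groups give matching numbers.

On these data alone, none of the three compounds moves the number beyond the scatter, so it remains unknown whether any group on this aromatic carbon can give a clearly stronger inhibitor. Open too, as far as these compounds go, is what a much smaller group such as methoxy, a phenyl ring carrying its own substituent, or a group of another kind such as an amine or a carboxylic acid would do here.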